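The compounds below may be only part of what the source reports. "The series", "measured", "known", "first", "only" and "open" are said of these compounds alone.

Three compounds have been measured so far in a physicochemical assay for solubility (a higher number here means a more soluble compound, a lower number a less soluble compound), with these results:

Compound 1 `Cc1nc(C)c(C(=O)Oc2ccc(-c3cc(=O)c4c(O)c(O)c(O)cc4o3)cc2)nc1C` gives 12.1 ug/mL
Compound 2 `Cc1nc(C)c(COC(=O)COc2ccc(-c3cc(=O)c4c(O)c(O)c(O)cc4o3)cc2)nc1C` gives 30.6 ug/mL
Compound 3 `Cc1nc(C)c(C(=O)NCC(=O)Oc2ccc(-c3cc(=O)c4c(O)c(O)c(O)cc4o3)cc2)nc1C` gives 628 ug/mL

Compound 3 stands highest of the three. Compound 2 lies nearest to it and compound 1 furthest from it, and both gaps are beyond the scatter.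

The compound still to be measured is compound 4 `Cc1nc(C)c(C(=O)N[C@@H](C(=O)Oc2ccc(-c3cc(=O)c4c(O)c(O)c(O)cc4o3)cc2)C(C)C)nc1C`, which differs from compound 3 in one place: isopropyl in place of hydrogen on a saturated chain carbon bound to an amide-type nitrogen and a carbonyl carbon.

Within the data shown here, no two measured compounds differ in only one place, so the data hold no direct precedent for this change, and any forecast is uncertain. With compound 3 at 628 ug/mL as the top value of the three, a fall seems more likely than a rise. The expected step in this assay is therefore a moderate one downward, beyond the scatter. The estimated change is a 3.5-fold lower number from compound 3 to compound 4 (0.54 log units; beyond the scatter) in this direction. For compound 4 the expected value is 180 ug/mL, within an estimated range from 50 ug/mL to 550 ug/mL.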

Compound 4, solubility: 240 ug/mL
Compound 4: the middle estimate sits 1.3-fold (0.12 log units) below what was measured, and the stated range covers the measured number.
By their numbers in this assay, from the lowest: compound 1; then compound 2; then compound 4; then compound 3.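

In this assay, among these compounds, replacing hydrogen with isopropyl on a saturated chain carbon bound to an amide-type nitrogen and a carbonyl carbon gives a 2.6-fold lower number from compound 3 to compound 4 (0.42 log units; beyond the scatter), the first reading of a single change at one place. It shows that this position can carry a branched group of 3 heavy atoms with only a modest fall, and compound 4 still reaches 240 ug/mL in this read-out. No measurement at hand bears on why the number falls at this position.

With a single step at this carbon, the compounds shown leave open whether the fall grows with the size of the group, since a methyl, a longer chain or a phenyl ring in the same place could land anywhere relative to isopropyl. Also open, on these data alone, is how an amine or a carboxylic acid on this chain would compare, and whether the mirror-image form at this carbon would give the same number as compound 4.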